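Swapping the Aryl Ring on a Piperazine Dithiocarbamate

This account rests on a few compounds, and the source may have more. Where it says the series, first, only, none or still open, it means among the compounds named here.

Measured so far in a functional assay on A-375 cells (Homo sapiens) for antiproliferative activity, read by CCK-8 assay, with a stated time of 72 h, tested at 2 uM; on this read-out lower numbers stand for a weaker effect and higher numbers for a stronger effect at the one concentration tested:
- compound 1 `Nc1ccccc1NC(=O)c1ccc(CSC(=S)N2CCN(c3ccc(Cl)cc3)CC2)cc1` gives 32.2%
- compound 2 `Nc1ccccc1NC(=O)c1ccc(CSC(=S)N2CCc3cc([N+](=O)[O-])ccc32)cc1` gives 16.9%
- compound 3 `CCN(Cc1ccncc1)C(=S)SCc1ccc(C(=O)Nc2ccccc2N)cc1` gives 67.2%

All three share the same core, a benzamide carrying an aminophenyl group and a dithiocarbamate linked through a benzylic sulfur; they differ only in the amine end. Among these three numbers in this assay compound 1 stands second highest. Its nearest neighbour is compound 2, whose value sits lower by a gap beyond the usual scatter, while compound 3 lies furthest away, higher by a gap that is also beyond the scatter.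

The next compound keeps the piperazine of compound 1 and changes only the aryl group on it. Compound 4 `Nc1ccccc1NC(=O)c1ccc(CSC(=S)N2CCN(c3ccccc3F)CC2)cc1` differs from compound 1 as follows: 2-fluorophenyl in place of 4-chlorophenyl on an amine nitrogen in a ring

Within the data shown here, no pair of measured compounds isolates such a change, so there is no measured step to lean on. One halogenated phenyl ring replaces another of the same size and the same count of donors and acceptors, so the expected step in this assay from compound 1 is small, roughly within the scatter, if anything slightly downward, an expected change of a number 4.2 percentage points lower from compound 1 to compound 4 (within the scatter). Compound 4 is therefore estimated at 28%, within a range from 12% to 45%.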

Compound 4, a percentage reported as inhibition, at one concentration (the size of the read-out at that concentration, not a potency): 18.7%
Compound 4: the middle estimate sits 9.3 percentage points above what was measured; the measured number falls inside the stated range.
By their numbers in this assay, from the lowest: compounds 2 and 4 (each within the scatter of the next); then compound 1; then compound 3.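

In this assay, the change gives a number 13.5 percentage points lower from compound 1 to compound 4 (beyond the scatter), so this place on the ring is not indifferent to which halogenated phenyl it carries. The 4-chlorophenyl and 2-fluorophenyl groups have the same count of heavy atoms, the same aromatic ring and no hydrogen-bond donors or acceptors, so these counts alone do not settle the read-out here. The step changes both the halogen and where it sits on the phenyl ring, and no information is available on why the number fell.

Among these compounds, with only this pair, the effect of the halogen cannot be separated from the effect of its location, and a fluorophenyl group carrying its fluorine where compound 1 carries its chlorine would be needed to pull the two apart. A plain phenyl group with no halogen, or a methoxyphenyl group, would show whether the ring needs a halogen at all to reach the level of compound 1.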